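The source may hold more compounds than are shown below. What is called first, only, known or untested is meant among the compounds shown, and "the series" means these compounds.

Compound 1 `OC[C@H]1O[C@@H](n2cnc3c(NCc4ccc(Br)cc4)ncnc32)[C@H](O)[C@@H]1O`, compound 2 `COc1ccccc1CNc1ncnc2c1ncn2[C@@H]1O[C@H](CO)[C@@H](O)[C@H]1O` and compound 3 `COc1cc(CNc2ncnc3c2ncn3[C@@H]2O[C@H](CO)[C@@H](O)[C@H]2O)cc(OC)c1O` share one core and differ only in the group carried on the saturated chain carbon bound to a nitrogen on the aromatic ring. In a functional assay on CCRF-CEM cells (Homo sapiens) for antiproliferative activity, with a stated time of 72 h (on this read-out higher numbers stand for weaker inhibition and lower numbers for stronger inhibition), compound 1 gives 20600 nM, while compound 2 gives 3200 nM; for compound 3 the entry is "not determined" (no result reported). Among the compounds with values here, the one step with numbers on both sides is a 6.4-fold lower number from compound 1 to compound 2 (0.81 log units; beyond the scatter), a modest change from swapping one aryl group for another at this position. Compound 2 therefore holds the lowest of the two numbers.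

Compound 4 `Cc1ccc(O)c(CNc2ncnc3c2ncn3[C@@H]2O[C@H](CO)[C@@H](O)[C@H]2O)c1` carries the difference (2-hydroxy-5-methylphenyl in place of 2-methoxyphenyl on a saturated chain carbon bound to a nitrogen on an aromatic ring). Within the data shown here, only the step from compound 1 to compound 2 bears on this, and it shows that changing the aryl group here moves the read-out modestly, not dramatically. The new group keeps the same count of heavy atoms and gains one hydrogen-bond donor, so a small shift in either direction, or none beyond the scatter, is expected. The expected change is a 1.1-fold lower number from compound 2 to compound 4 (0.03 log units; within the scatter). Compound 4 is expected to give 3000 nM, with a range from 800 nM to 12000 nM.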

Compound 4, half-maximal inhibitory concentration: 1900 nM
Estimate against measurement, compound 4: 1.6-fold (0.20 log units) above; low and high end bracket the measured number.
By their numbers in this assay, from the lowest: compounds 4 and 2 (each within the scatter of the next); then compound 1.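

Swapping the 2-methoxyphenyl group for 2-hydroxy-5-methylphenyl, which adds a hydrogen-bond donor while keeping the same heavy atoms, gives a 1.7-fold lower number from compound 2 to compound 4 (0.23 log units; within the scatter) in this assay and so leaves no real difference between the two groups at this position. Set against the 4-bromophenyl group, the new group gives an 11-fold lower number from compound 1 to compound 4 (1.04 log units; beyond the scatter) and, like the 2-methoxyphenyl group, stands clear of compound 1, so this position tolerates at least two differently substituted aryl groups with similar results. No evidence here explains why compound 1 gives the higher number.

Compound 4 changes two things on the ring at once, so the effect of the hydroxyl cannot be separated from that of the methyl. As far as these compounds go, a plain 2-hydroxyphenyl group would address that, while an aminophenyl group or a longer chain between the nitrogen and the ring remains unexplored here.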